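Aryl Swap on the Triazole of a Triterpenoid Ester

The source may hold more compounds than are shown below. What is called first, only, known or untested is meant among the compounds shown, and "the series" means these compounds.

Measured compounds:
Compound 1 `COc1ccccc1-n1cc(COC(=O)/C(C)=C/CC/C(C)=C/CC/C(C)=C/CC[C@@H]2[C@@]3(C)CCC(=O)C(C)(C)[C@H]3CC[C@@]2(C)O)nn1` — > 150000 nM
Compound 2 `C/C(=C\CC/C(C)=C/CC[C@@H]1[C@@]2(C)CCC(=O)C(C)(C)[C@H]2CC[C@@]1(C)O)CC/C=C(\C)C(=O)OCc1cn(-c2ccccc2C(F)(F)F)nn1` — > 150000 nM
Compound 3 `C/C(=C\CC/C(C)=C/CC[C@@H]1[C@@]2(C)CCC(=O)C(C)(C)[C@H]2CC[C@@]1(C)O)CC/C=C(\C)C(=O)OCc1cn(-c2ccc(F)c(Cl)c2)nn1` — > 150000 nM

Three esters share one triterpenoid core and differ only in the aryl group on the triazole nitrogen. In a functional assay on A549 cells (Homo sapiens) for antiproliferative activity, read by MTT assay, with a stated time of 48 h (a lower number here means a stronger inhibitor, a higher number a weaker inhibitor), compound 2 reaches no number at all; the value reported for it, > 150000 nM, is a limit of the assay. The same holds for compound 1, whose result > 150000 nM is also a limit. Compound 3 likewise gives only the limit > 150000 nM. The three steps among them, a step that the two limits leave unreadable from compound 1 to compound 2, a step that the two limits leave unreadable from compound 1 to compound 3 and a step that the two limits leave unreadable from compound 2 to compound 3, therefore cannot be sized, as summarised in the limit of > 150000 nM in this assay, at which 3 of the 3 values shown sit.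

The next compound, compound 4 `C/C(=C\CC/C(C)=C/CC[C@@H]1[C@@]2(C)CCC(=O)C(C)(C)[C@H]2CC[C@@]1(C)O)CC/C=C(\C)C(=O)OCc1cn(-c2ccc(Br)cc2)nn1`, is reached from compound 2 by the change (4-bromophenyl in place of 2-(trifluoromethyl)phenyl on an aromatic nitrogen). Since every aryl variant measured so far sits at the limit, there is no evidence that this position moves the read-out within the measurable window, and the expectation is that compound 4 will again lie at or beyond the limit. The step that the limit leaves unreadable from compound 2 to compound 4 is expected to be nil within the scatter. Compound 4 is therefore estimated at 200000 nM, with a range from 100000 nM to 400000 nM.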

Compound 4, half-maximal inhibitory concentration: > 150000 nM
Compound 4 gave a limit, no number; the forecaster's own chance of this, stated with the estimate: 85%; the middle value does not contradict the limit.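

In this assay compound 4 gives > 150000 nM as a limit, not a number. Its steps from compound 1, compound 2 and compound 3 therefore cannot be read, and all four compounds stand at the same limit: the limit of > 150000 nM in this assay, at which 4 of the 4 values shown sit. The compounds shown leave open whether any aryl group on the triazole nitrogen of this ester can bring a value inside the readable range of this assay at all.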